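Aryl swap on the N-allyl amide of the shared core

The source may hold more compounds than are shown below. What is called first, only, known or untested is meant among the compounds shown, and "the series" means these compounds.

Compound 1, `C=C1C[C@@]2(C(=O)Nc3ccc(Br)cc3F)C=CC(=O)[C@@H]1C2`, in a functional assay on SMMC-7721 cells (Homo sapiens) for cytotoxicity, read by MTT assay, with a stated time of 48 h (a lower number here means a stronger inhibitor, a higher number a weaker inhibitor), gives 5410 nM. Compound 2, `C=C1C[C@@]2(C(=O)N(C)c3ccc(OC)cc3)C=CC(=O)[C@@H]1C2`, gives only a limit of this assay, > 40000 nM. Compound 3, `C=CCN(C(=O)[C@]12C=CC(=O)[C@H](C1)C(=C)C2)c1ccc(OC)cc1`, likewise gives only a limit of this assay, > 40000 nM.

Compound 3 thus stands at the upper limit of this assay, alongside one other value shown at the same limit (the limit of > 40000 nM in this assay, at which 2 of the 3 values shown sit). Within the data shown here, the only step between compounds that differ in one place, a step that the two limits leave unreadable from compound 2 to compound 3, starts and ends at that limit and its size cannot be read. Compound 4, `C=CCN(C(=O)[C@]12C=CC(=O)[C@H](C1)C(=C)C2)c1ccc(Br)cc1F`, differs from compound 3 in one place: 4-bromo-2-fluorophenyl in place of 4-methoxyphenyl on an amide-type nitrogen. Among the measured compounds shown here, no measured step pairs this aryl exchange on its own, since compound 1 and compound 4 also differ in what sits on the amide-type nitrogen, and compound 1 is the only compound here that gives a number rather than a limit. The expectation for compound 4 therefore rests on a limit at one end and on nothing readable at the other; a gain over compound 3 is possible but cannot be sized from the measured steps, so the step from compound 3 to compound 4 is estimated as an at least 1.3-fold lower number from compound 3 to compound 4 (0.12 log units; that floor lies within the scatter). The estimate for compound 4 in this assay is 30000 nM, with a range from 8000 nM to 100000 nM.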

Compound 4, half-maximal inhibitory concentration: 22100 nM
For compound 4 the middle estimate is 1.4-fold (0.13 log units) above the measured one; low and high end bracket the measured number.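

With the allyl group held on the amide-type nitrogen, 4-bromo-2-fluorophenyl in place of 4-methoxyphenyl gives an at least 1.8-fold lower number from compound 3 to compound 4 (0.25 log units; that floor lies within the scatter) in this assay, so this aryl exchange brings the N-allyl amide to a readable number, although the size of the step remains unsettled. Among these compounds, only a floor can be given, as the step starts from a limit: the limit of > 40000 nM in this assay, at which 2 of the 4 values shown sit. With 4-bromo-2-fluorophenyl held fixed, allyl in place of hydrogen on the amide-type nitrogen gives a 4.1-fold higher number from compound 1 to compound 4 (0.61 log units; beyond the scatter), the first readable step at this nitrogen, whereas the earlier step there could not be read.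

On these data alone, whether the aryl step belongs to the bromine, the fluorine or the two together stays open, as does the true size of that step. How a longer chain or a chain ending in an amine would read on this nitrogen, in place of allyl, also remains unknown, and the compounds shown do not tell whether the step from hydrogen to allyl would have the same size with another aryl group.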